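Swapping a dichlorophenyl amide for a fluoropyridine amide

The source may report more compounds than this note shows. Statements on the series, on what has been measured and on what is new or still open speak of the compounds shown alone.

Measured compounds:
- compound 1 `CNC(=O)c1cc(Oc2ccc3nc(NC(=O)c4ccc(Cl)cc4Cl)sc3c2)ccn1`: 81%
- compound 2 `CNC(=O)c1cc(Oc2ccc3nc(NC(=O)c4ccc(Cl)cc4)sc3c2)ccn1`: 83%
- compound 3 `CNC(=O)c1cc(Oc2ccc3nc(NC(=O)Nc4ccc(N5CCN(C)CC5)cc4)sc3c2)ccn1`: 86.4%

All three were tested in a functional assay on SK-BR-3 cells (Homo sapiens) for inhibition, read by MTT assay, with a stated time of 2 days, tested at 100 uM; on this read-out higher numbers stand for more inhibition of growth at the one concentration tested and lower numbers for less inhibition of growth. On the numbers shown, compound 1 has the lowest of the three; the gap to compound 2 is a number 2 percentage points higher from compound 1 to compound 2 (within the scatter), and the number for compound 3 also lies within the scatter of compound 1, so the three compounds cannot be told apart by this read-out.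

Compound 4 `CNC(=O)c1cc(Oc2ccc3nc(NC(=O)c4cccc(F)n4)sc3c2)ccn1` has not yet been measured. It differs from compound 1 by 6-fluoropyridin-2-yl in place of 2,4-dichlorophenyl on a carbonyl carbon; cut one bond further out, the change reads (2,4-dichlorophenyl)carbonyl to (6-fluoropyridin-2-yl)carbonyl.

Among the compounds with values here, only one measured step touches this part of the shared core: the step from compound 1 to compound 2, which removes one chloro group and reads a number 2 percentage points higher from compound 1 to compound 2 (within the scatter), within the scatter. Compound 3 differs from compound 1 in more than one place, so its value can only be set beside that of compound 1, where it is also within the scatter. Nothing here points to a step beyond the scatter, so no step beyond the scatter is expected in this assay.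

The expected step is therefore a number 2 percentage points lower from compound 1 to compound 4 (within the scatter). Compound 4 is estimated at 79%, with a range from 62% to 91%.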

Compound 4, percent growth inhibition at one concentration: 89.4%
Estimate against measurement, compound 4: 10.4 percentage points below, and the stated range covers the measured number.
By their numbers in this assay, from the lowest: compounds 1, 2, 3 and 4 (each within the scatter of the next).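

In this assay putting 6-fluoropyridin-2-yl in place of 2,4-dichlorophenyl on the carbonyl carbon gives a number 8.4 percentage points higher from compound 1 to compound 4 (within the scatter) and putting it in place of 4-chlorophenyl gives a number 6.4 percentage points higher from compound 2 to compound 4 (within the scatter) so both steps stay inside the normal spread of repeat measurements. Within the data shown here, until now the only step at this position had removed one chloro group and kept a carbon-only aromatic ring, whereas these two show that a ring with a hetero atom and no chlorine can take its place with no difference this read-out can detect at the one concentration tested. No measurement is available that would explain this tolerance.

As far as these compounds go, all four compounds sit close together at that single concentration, so it remains open whether they would separate at lower concentrations, where a full dose-response curve could reveal differences. Also open, from the compounds shown here alone, is how a different kind of group on this carbonyl carbon would behave, such as a plain pyridin-2-yl without fluorine, a piperidine amine, a carboxylic acid or a longer alkyl chain.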